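A larger branched ester on the core of compound 3

This account rests on a few compounds, and the source may have more. Where it says the series, first, only, none or still open, it means among the compounds named here.

Three esters of a shared core have been measured for how strongly they slow the growth of a breast-cancer cell line. In a functional assay on SK-BR-3 cells (Homo sapiens) for antiproliferative activity, read by MTT assay, with a stated time of 72 h (a higher number here means a weaker inhibitor, a lower number a stronger inhibitor), compound 1 `C/C=C1/[C@H](O[C@@H]2O[C@H](COC(C)=O)[C@@H](OC(C)=O)[C@H](OC(C)=O)[C@H]2OC(C)=O)OC=C(C(=O)OC)[C@H]1CC(=O)OCCC` gives 6600 nM. Compound 2 `C/C=C1/[C@H](O[C@@H]2O[C@H](COC(C)=O)[C@@H](OC(C)=O)[C@H](OC(C)=O)[C@H]2OC(C)=O)OC=C(C(=O)OC)[C@H]1CC(=O)OCC` reaches only a limit of the assay in this assay, > 15000 nM, marked by the limit of > 15000 nM in this assay, at which 1 of the 3 values shown sits. Compound 3 `C=CCOC(=O)C[C@@H]1C(C(=O)OC)=CO[C@@H](O[C@@H]2O[C@H](COC(C)=O)[C@@H](OC(C)=O)[C@H](OC(C)=O)[C@H]2OC(C)=O)/C1=C/C` likewise stands at a limit, > 20000 nM, marked by the limit of > 20000 nM in this assay, at which 1 of the 3 values shown sits, so for compound 3 only a range is known, and it is the weakest of the three as far as the numbers go.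

Compound 4 `C=C(C)CCOC(=O)C[C@@H]1C(C(=O)OC)=CO[C@@H](O[C@@H]2O[C@H](COC(C)=O)[C@@H](OC(C)=O)[C@H](OC(C)=O)[C@H]2OC(C)=O)/C1=C/C` differs from compound 3 by 2-methylprop-2-en-1-yl in place of vinyl on a saturated chain carbon bound to an oxygen next to a carbonyl group. The measured steps show that a shorter or unsaturated ester chain weakens the effect: an at least 2.2-fold higher number from compound 1 to compound 2 (0.35 log units; beyond the scatter) and an at least 3.0-fold higher number from compound 1 to compound 3 (0.48 log units; beyond the scatter). The step that the two limits leave unreadable from compound 2 to compound 3 cannot be read because both ends are limits. Compound 4 carries a longer ester chain than any of the three, in the direction that helped compound 1, so its number is expected to fall, although a limit cannot be ruled out. The expected step is an at least 2.2-fold lower number from compound 3 to compound 4 (0.34 log units; beyond the scatter). Compound 4 is therefore estimated at 9000 nM, within a range from 3000 nM to 25000 nM.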

Compound 4, half-maximal inhibitory concentration: > 15000 nM
Compound 4: no number, only a limit; the forecaster's own chance of this, stated with the estimate: 35%; middle value at least 1.6-fold (0.22 log units) from the limit.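

Compound 4 gives only a limit of the assay in this assay, not a number: the limit of > 15000 nM in this assay, at which 2 of the 4 values shown sit. Its longer, branched 3-methylbut-3-en-1-yl ester chain still falls short of the ester of the shared core that gives a real number, with an at least 2.2-fold higher number from compound 1 to compound 4 (0.35 log units; beyond the scatter), so among these four esters, added chain length alone does not restore the effect seen for compound 1. The steps among compound 2, compound 3 and compound 4 cannot be read, as both ends of each are limits, so these three esters cannot be ranked against one another, and the new result shows only that all three stay short of compound 1.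

The compounds shown leave open whether the double bond, the branch or the chain length counts against compound 4, and a saturated chain such as a butyl or 3-methylbutyl ester would help to separate these. They also leave open whether any ester at this place can do better than compound 1, or whether a carboxylic acid or an amide there would give a readable number.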